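The source may report more compounds than this note shows. Statements on the series, on what has been measured and on what is new or still open speak of the compounds shown alone.

Compound 1 `O=C(Nc1cccc(C(F)(F)F)c1)c1cc(=O)[nH]c2cc(Br)ccc12` — > 20000 nM
Compound 2 `O=C(Nc1cccc(Cl)c1)c1cc(=O)[nH]c2cc(Br)ccc12` — > 20000 nM
Compound 3 `O=C(Nc1cc(F)cc(F)c1)c1cc(=O)[nH]c2cc(Cl)ccc12` — 11000 nM

In a functional assay on KYSE-410 cells (Homo sapiens) for antiproliferative activity, read by MTT assay, with a stated time of 72 h (on this read-out lower numbers stand for stronger inhibition and higher numbers for weaker inhibition), compound 1 gives > 20000 nM, which is a limit of the assay and not a number. Compound 2 likewise gives > 20000 nM, again a limit. Compound 3 is the only one of the three with a measured number, giving 11000 nM in this assay. The change trifluoromethyl in place of chloro on an aromatic carbon produces a step that the two limits leave unreadable from compound 2 to compound 1; its size cannot be read because both values sit at the limit of > 20000 nM in this assay, at which 2 of the 3 values shown sit. The difference between the core of compound 2 and the core of compound 3 is not broken down here.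

Compound 4 `O=C(Nc1cc(F)cc(F)c1)c1cc(=O)[nH]c2cc(C(F)(F)F)ccc12` has not yet been measured. It arises from compound 3 by trifluoromethyl in place of chloro on an aromatic carbon. This is the same kind of change as that from compound 2 to compound 1, though the place differs: there the change sat on a six-membered aromatic ring of carbon only, meta to a large group, here it sits on a ring that is part of a fused or bridged system of two rings, meta to a fused ring and para to a fused ring. Since the earlier step was unreadable, the expectation rests mainly on compound 3 and its value 11000 nM. Compound 4 is therefore estimated at 15000 nM in this assay, between 5000 nM and 40000 nM, meaning an expected step of a 1.4-fold higher number from compound 3 to compound 4 (0.13 log units; within the scatter).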

Compound 4, half-maximal inhibitory concentration: 17900 nM
The estimate for compound 4 lay 1.2-fold (0.08 log units) below the measured number, and the stated range covers the measured number.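

In this assay, trifluoromethyl in place of chloro on an aromatic carbon of the core of compound 3 gives a 1.6-fold higher number from compound 3 to compound 4 (0.21 log units; within the scatter) and so leaves the two compounds within the usual scatter of each other. The same kind of change in a different place, from compound 2 to compound 1, cannot be read, because neither compound has a number, only a limit of the assay: the limit of > 20000 nM in this assay, at which 2 of the 4 values shown sit. The series therefore shows one readable case in which this change makes no difference beyond the scatter, but it does not show whether the change behaves alike from one core to another.

The compounds shown leave open whether a different group in place of chloro on the core of compound 3, such as an amine, a carboxylic acid or a longer chain, would move the number beyond the scatter. They also leave open what a methyl group in place of the amide hydrogen would do.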